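Methyl to tert-Butyl at the End of the Shared Core

This account rests on a few compounds, and the source may have more. Where it says the series, first, only, none or still open, it means among the compounds named here.

Of the compounds shown here, three built on one core have been tested in a functional assay on HEK293 cells for agonist activity at Free fatty acid receptor 1 (Homo sapiens), read by fluorescence and calcium flux; on this read-out lower numbers stand for an effect already at smaller amounts and higher numbers for an effect only at larger amounts of compound. Compound 1 `CC#CC(CC(=O)O)c1ccc(OCc2ccc(C(=O)N3CCN(c4ccncc4)CC3)s2)cc1` reaches only a limit there, > 5000 nM. Compound 2 `CC#CC(CC(=O)O)c1ccc(OCc2ccc(C(=O)N3CCN(c4cccnc4)CC3)s2)cc1` gives 1140 nM in this assay, and compound 3 `CC#CC(CC(=O)O)c1ccc(OCc2ccc(C(=O)N3CCN(c4ccc(C)cc4)CC3)s2)cc1` gives 211 nM, the lowest of the two numbers shown. Putting pyridin-3-yl in place of pyridin-4-yl on the amine nitrogen in the ring brings an at least 4.3-fold lower number from compound 1 to compound 2 (0.64 log units; beyond the scatter); moving on from pyridin-3-yl to 4-methylphenyl brings a 5.4-fold lower number from compound 2 to compound 3 (0.73 log units; beyond the scatter), and the two changes together amount to an at least 23-fold lower number from compound 1 to compound 3 (1.37 log units; beyond the scatter).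

Compound 4 `CC#CC(CC(=O)O)c1ccc(OCc2ccc(C(=O)N3CCN(c4ccc(C(C)(C)C)cc4)CC3)s2)cc1` differs from compound 3 by tert-butyl in place of methyl on an aromatic carbon. Within the data shown here, none of the measured steps touches this position: all three concern the exchange of the whole group on the amine nitrogen in the ring, where both pyridinyl groups gave higher numbers than 4-methylphenyl. The change from methyl to tert-butyl is of a different kind, so those steps offer no direct guide, and the step expected in this assay is a 1.2-fold higher number from compound 3 to compound 4 (0.07 log units; within the scatter), a modest shift that may well lie within the scatter. Compound 4 is therefore estimated at 250 nM, with a range from 80 nM to 800 nM.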

Compound 4, half-maximal effective concentration: 417 nM
Compound 4: the middle estimate sits 1.7-fold (0.22 log units) below what was measured, and the stated range covers the measured number.
By their numbers in this assay, from the lowest: compounds 3 and 4 (each within the scatter of the next); then compound 2. At a limit, above all of these: compound 1.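

In this assay, the only change shown at this position, on an aromatic carbon para to a large group, is tert-butyl in place of methyl, with a 2.0-fold higher number from compound 3 to compound 4 (0.30 log units; within the scatter). Thus 4 heavy atoms in place of 1 at this position leave compounds 3 and 4 within the scatter of each other, and the larger group keeps the separation from both pyridinyl compounds: a 2.7-fold lower number from compound 2 to compound 4 (0.44 log units; beyond the scatter), and an at least 11-fold lower number from compound 1 to compound 4 (1.07 log units; beyond the scatter). The last of these steps rests on compound 1, whose value is a limit: the limit of > 5000 nM in this assay, at which 1 of the 4 values shown sits.

The compounds shown leave open how this position responds to groups other than methyl and tert-butyl, such as a methoxy group, a trifluoromethyl group, a chlorine atom or a carboxylic acid. They also leave open how an ethyl or isopropyl group at this position, or a plain phenyl ring with nothing on this carbon, would read in this assay.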